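Ethoxy to methyl on the pendant aryl ring: compound 4

The compounds below may be only part of what the source reports. "The series", "measured", "known", "first", "only" and "open" are said of these compounds alone.

Measured so far in an assay on COS-7 cells for inhibition of patatin-like phospholipase domain-containing protein 2 (Mus musculus), tested at 200 uM; a lower number here means less inhibition, a higher number more inhibition at the concentration tested (going by the name of the read-out):
- compound 1, `CCOC(=O)c1cccc(-c2ccc(OCC)cc2)n1`: 79%
- compound 2, `CCOC(=O)c1cccc(-c2ccc(OCC)cc2)c1`: 87%
- compound 3, `CCOC(=O)c1cccc(-c2ccsc2)c1`: 67%

Compound 2 stands at the top of the three numbers in this assay. The number for compound 1 is within the usual scatter of it, so these two cannot be told apart on the data shown. Compound 3 gives a number beyond the scatter below compound 2. Going by the values given here, no pair among the three measured compounds differs in one place only, so no single-change step is available as a yardstick.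

Compound 4, `CCOC(=O)c1cccc(-c2ccc(C)cc2)c1`, is the next compound and differs from compound 2 by methyl in place of ethoxy on an aromatic carbon. The change sits on the pendant ring and removes the ethoxy chain with its one hydrogen-bond acceptor while the rest of the structure is unchanged.

Without a measured step of this kind in the series, the size of the change in this assay is uncertain; a small loss or no change beyond the scatter is expected, with a larger loss not ruled out. The estimated step of a number 11 percentage points lower from compound 2 to compound 4 (beyond the scatter) is therefore expected to be modest. For compound 4 the expected number is 76%, with a range of 55% to 92%.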

Compound 4, a percentage reported as inhibition, at one concentration (the size of the read-out at that concentration, not a potency): 63%
For compound 4 the middle estimate is 13 percentage points above the measured one; low and high end bracket the measured number.
By their numbers in this assay, from the lowest: compounds 4 and 3 (each within the scatter of the next); then compounds 1 and 2 (each within the scatter of the next).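

In this assay the series gains its first single-change yardstick: methyl in place of ethoxy on an aromatic carbon para to a large group gives a number 24 percentage points lower from compound 2 to compound 4 (beyond the scatter) and so shows that the group at this place on the pendant ring affects the read-out. The step changes two counted features together, going from 3 heavy atoms and 1 hydrogen-bond acceptor in ethoxy to 1 heavy atom and 0 hydrogen-bond acceptors in methyl, so it cannot assign the drop to either feature alone. No measured evidence on the compounds shown accounts for the size of this step.

Methoxy at the same place would keep the ether oxygen with a shorter chain, while propyl would keep a chain without that oxygen, so the two would begin to separate chain length from the acceptor, and a longer chain such as butoxy would test whether the trend continues past ethoxy. Also open, as far as these compounds go, is whether the same swap on the core of compound 1 gives a step of similar size or whether this step holds only on the core of compound 2.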